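Sulfonamide nitrogen variation in a cytotoxicity series

A few compounds are considered here, and "the series" means these few. Any claim that something is new, unique, unknown or untested is made for them only; others in the source may bear on it.

In a functional assay on B16-F10 cells (Mus musculus) for cytotoxicity, read by CCK-8 assay, with a stated time of 48 h (a higher number here means a weaker inhibitor, a lower number a stronger inhibitor), compound 1 `CC(C)(C)c1cc(C(C)(C)C)c2oc(=O)c(/C=N/c3ccc(S(=O)(=O)Nc4nccs4)cc3)c(Cl)c2c1` gives 160 nM. In this assay compound 2 `CC(C)(C)c1cc(C(C)(C)C)c2oc(=O)c(/C=N/c3ccc(S(=O)(=O)NC(=N)N)cc3)c(Cl)c2c1` gives 250 nM. For the measured compounds named here, compound 2 stands highest of the two numbers measured so far; its only neighbour is compound 1, and the step of a 1.6-fold higher number from compound 1 to compound 2 (0.19 log units; within the scatter) lies within the scatter. Compound 3 `Cc1cc(NS(=O)(=O)c2ccc(/N=C/c3c(Cl)c4cc(C(C)(C)C)cc(C(C)(C)C)c4oc3=O)cc2)no1` differs from compound 2 by a group of 6 heavy atoms (4 carbon, 1 nitrogen, 1 oxygen; one five-membered aromatic ring with 2 hetero atoms) in place of a group of 3 heavy atoms (1 carbon, 2 nitrogen; no ring), on a sulfonamide nitrogen. Going by the values given here, the one measured step that bears on this change, a 1.6-fold higher number from compound 1 to compound 2 (0.19 log units; within the scatter), exchanged a five-membered aromatic ring with 2 hetero atoms on the sulfonamide nitrogen for the group of 3 heavy atoms and moved the number only within the scatter; compound 3 puts a five-membered aromatic ring with 2 hetero atoms back on that nitrogen. No step beyond the scatter is therefore expected in this assay, in either direction. Compound 3 is estimated at 180 nM in this assay, with a range of 80 nM to 400 nM. The expected step is a 1.4-fold lower number from compound 2 to compound 3 (0.14 log units; within the scatter).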

Compound 3, half-maximal inhibitory concentration: 240 nM
The estimate for compound 3 lay 1.3-fold (0.12 log units) below the measured number; the measured number falls inside the stated range.
By their numbers in this assay, from the lowest: compounds 1, 3 and 2 (each within the scatter of the next).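

In this assay, for the compounds shown here, the sulfonamide nitrogen now carries three different groups, and no step among the new pairs leaves the scatter: a 1.0-fold lower number from compound 2 to compound 3 (0.02 log units; within the scatter), and a 1.5-fold higher number from compound 1 to compound 3 (0.18 log units; within the scatter). The second step is a direct exchange of one five-membered aromatic ring with 2 hetero atoms for another, 5-methyl-1,2-oxazol-3-yl in place of 1,3-thiazol-2-yl, and the ringless group of compound 2 lies within the scatter of both, so across these three compounds the presence of a ring on that nitrogen does not separate the numbers. No measurement at hand accounts for this result.

Still open, on these data alone, is whether a pyridin-2-yl ring, a plain methyl or a chain ending in a carboxylic acid on the sulfonamide nitrogen would stay within the same scatter. The compounds shown also leave open how changes elsewhere on the shared core would read.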